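Shifting a Ring Hydroxyl in a Solubility Series

The source may hold more compounds than are shown below. What is called first, only, known or untested is meant among the compounds shown, and "the series" means these compounds.

Compound 1 `O=C(/C=C/c1ccccc1O)CC(=O)/C=C/c1cc(O)ccc1O` and compound 2 `O=C(/C=C/c1cccc(O)c1)CC(=O)/C=C/c1cc(O)ccc1O` are built on one core, while compound 3 `O=C(/C=C/c1ccc(O)c(O)c1)/C=C/c1ccccc1O` and compound 4 `O=C(/C=C/c1cccc(O)c1)/C=C/c1ccc(O)c(O)c1` are built on another; the difference between the two cores is not broken down here. In a physicochemical assay for solubility, using the shake flask method, with a stated time of 12 h (on this read-out higher numbers stand for higher solubility and lower numbers for lower solubility), compound 1 gives 4400 nM, and compound 2 gives 5800 nM. The two differ by 3-hydroxyphenyl in place of 2-hydroxyphenyl on a double-bonded chain carbon bound to a double-bonded chain carbon, and that change made a 1.3-fold higher number from compound 1 to compound 2 (0.12 log units; within the scatter). In this assay compound 3 gives 111000 nM, the highest of the three measured numbers, beyond the scatter from both compound 1 and compound 2. Compound 4 has not yet been measured. It differs from compound 3 by 3-hydroxyphenyl in place of 2-hydroxyphenyl on a double-bonded chain carbon bound to a double-bonded chain carbon, the same change that turned compound 1 into compound 2, made at the same kind of position in the chain. Because that earlier step was a 1.3-fold higher number from compound 1 to compound 2 (0.12 log units; within the scatter), the corresponding step is expected to be small, around a 1.3-fold higher number from compound 3 to compound 4 (0.10 log units; within the scatter). In this assay compound 4 is therefore estimated at 140000 nM, with a likely range from 60000 nM to 320000 nM, close to what compound 3 showed.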

Compound 4, solubility: 60000 nM
Compound 4: middle estimate off by 2.3-fold (0.37 log units), on the high side; the measured number falls inside the stated range.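

In this assay, 3-hydroxyphenyl in place of 2-hydroxyphenyl gave a 1.9-fold lower number from compound 3 to compound 4 (0.27 log units; within the scatter), while on the core of compound 1 the same change gave a 1.3-fold higher number from compound 1 to compound 2 (0.12 log units; within the scatter). Both steps lie within the scatter, so the finding that this change leaves no readable difference carried from one core to the other, and no direction can be claimed for it on either core. Going by these compounds alone, this rests on only two pairs and does not show that the change would stay this small on other cores, and nothing available here bears on what lies behind the result.

The compounds shown leave open whether the picture would hold with an amine or a carboxylic acid in place of the hydroxyl on this ring. They also leave open whether a methoxy group there, or a longer chain between the ring and the carbonyl, would give a step beyond the scatter.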